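Swapping Sulfur for Selenium on a Cyano-Bearing Side Chain

A few compounds are considered here, and "the series" means these few. Any claim that something is new, unique, unknown or untested is made for them only; others in the source may bear on it.

Compound 3, with the structure `N#CSCN1C(=O)c2ccccc2C1=O`, has been tested in a functional assay on MCF7 cells (Homo sapiens) for cytotoxicity, read by MTT assay, with a stated time of 72 h (a higher number here means a weaker inhibitor of growth, a lower number a stronger inhibitor of growth), and gives only a limit of the assay, > 100000 nM. Its parent compound 1, `O=C1c2ccccc2C(=O)N1CS`, likewise reaches only a limit in this assay, > 100000 nM. For the measured compounds named here, compound 2, `O=C1c2ccccc2C(=O)N1C[SeH]`, is the one member of the set with a number: in this assay compound 2 gives 8200 nM. Two of the three values therefore sit at the limit of > 100000 nM in this assay, at which 2 of the 3 values shown sit.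

The change now followed is a group of 3 heavy atoms (1 carbon, 1 nitrogen, 1 selenium; no ring) in place of a group of 3 heavy atoms (1 carbon, 1 nitrogen, 1 sulfur; no ring), on a saturated chain carbon bound to an amide-type nitrogen in a ring, which gives compound 4, `N#C[Se]CN1C(=O)c2ccccc2C1=O`. Going by the values given here, one measured step bears on it most directly: the step of an at least 12-fold lower number from compound 1 to compound 2 (1.08 log units; beyond the scatter), the same exchange of sulfur for selenium made on the chain that carries hydrogen rather than cyano. The step that the two limits leave unreadable from compound 1 to compound 3 has no readable size, and the step of an at least 12-fold higher number from compound 2 to compound 3 (1.08 log units; beyond the scatter) combines the element swap with the cyano group, so neither can separate the two effects.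

On the strength of the selenium step alone, a large drop in number from compound 3 to compound 4 is expected, an at least 6.6-fold lower number from compound 3 to compound 4 (0.82 log units; beyond the scatter). Compound 4 is therefore estimated at 15000 nM, with a plausible range from 3000 nM to 100000 nM, while a further limit remains possible.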

Compound 4, concentration for total growth inhibition: 56100 nM
For compound 4 the middle estimate is 3.7-fold (0.57 log units) below the measured one, and the stated range covers the measured number.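

What compound 4 adds is a first number for a cyano-bearing chain in this assay, and with selenium in that chain the step reads an at least 1.7-fold lower number from compound 3 to compound 4 (0.25 log units; that floor lies within the scatter), a floor whose true size stays unknown because one end of it is a limit of the assay: the limit of > 100000 nM in this assay, at which 2 of the 4 values shown sit.

For the compounds shown here, the firmest new comparison stays on selenium, where the step reads a 6.8-fold higher number from compound 2 to compound 4 (0.84 log units; beyond the scatter), so the added cyano goes with weaker growth inhibition, and this is the only step in the set with a real number at both ends. The step of an at least 1.7-fold lower number from compound 1 to compound 4 (0.25 log units; that floor lies within the scatter) is again only a floor, so the large gain seen with selenium on the chain that carries hydrogen cannot be said to carry over at full size to the cyano-bearing chain.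

The compounds shown leave open how large the exchange of sulfur for selenium on the cyano-bearing chain really is. They also leave open how this assay would read with a methyl group on the selenium, or with a longer chain ending in an amine or a carboxylic acid.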